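The source may report more compounds than this note shows. Statements on the series, on what has been measured and on what is new or still open speak of the compounds shown alone.

Compound 2 `CCN(CC)CCNC(=O)c1ccc(C(CC)(CC)c2ccc(OCS(=O)(=O)c3ccccc3)c(C)c2)n1CC` gives 7130 nM in a functional assay on PC-3 cells (Homo sapiens) for antiproliferative activity, read by MTT assay, with a stated time of 24 h (on this read-out lower numbers stand for stronger inhibition and higher numbers for weaker inhibition), and stands second highest of the three numbers, nearest to compound 1 `CCn1c(C(=O)N[C@@H](CC(=O)OC)C(=O)OC)ccc1C(CC)(CC)c1ccc(OCS(=O)(=O)c2ccccc2)c(C)c1`, which gives 6490 nM, and furthest from compound 3 `CCn1c(C(=O)NCCCO)ccc1C(CC)(CC)c1ccc(OCS(=O)(=O)c2ccccc2)c(C)c1`, which gives 11300 nM, both gaps lying within the scatter. Compound 4 `CCn1c(C(=O)N[C@@H](C(=O)O)C(C)C)ccc1C(CC)(CC)c1ccc(OCS(=O)(=O)c2ccccc2)c(C)c1` differs from compound 2 in one place: 1-carboxy-2-methylpropyl in place of 2-(diethylamino)ethyl on an amide-type nitrogen. Three measured steps change the group on this same amide-type nitrogen, and all were small: a 1.1-fold higher number from compound 1 to compound 2 (0.04 log units; within the scatter), a 1.7-fold higher number from compound 1 to compound 3 (0.24 log units; within the scatter) and a 1.6-fold higher number from compound 2 to compound 3 (0.20 log units; within the scatter). Compound 1, carrying a related 1,2-bis(methoxycarbonyl)ethyl group at that nitrogen, gives 6490 nM, so the new group is not expected to move the number beyond the scatter. For compound 4 the expected step is a 1.1-fold lower number from compound 2 to compound 4 (0.04 log units; within the scatter). Compound 4 is therefore estimated at 6500 nM, within 3000 nM to 14000 nM.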

Compound 4, half-maximal inhibitory concentration: 3070 nM
The estimate for compound 4 lay 2.1-fold (0.33 log units) above the measured number; low and high end bracket the measured number.
By their numbers in this assay, from the lowest: compound 4; then compounds 1, 2 and 3 (each within the scatter of the next).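

The amide-type nitrogen, where the earlier changes all stayed within the scatter, does respond in this assay: 1-carboxy-2-methylpropyl gives a 2.3-fold lower number from compound 2 to compound 4 (0.37 log units; beyond the scatter), a 3.7-fold lower number from compound 3 to compound 4 (0.57 log units; beyond the scatter) and a 2.1-fold lower number from compound 1 to compound 4 (0.33 log units; beyond the scatter). Compound 4 is thus the only one of the four whose steps to all the others lie beyond the scatter, and its group is the only one shown with a free carboxy group. Nothing available explains this step. The compounds shown do not separate the carboxy group from the branched chain that carries it, so it stays open whether the corresponding methyl ester or an unbranched carboxylic acid chain on this nitrogen would give a similar number.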